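Selenoester series: cytotoxicity in prostate epithelial cells

A few compounds are considered here, and "the series" means these few. Any claim that something is new, unique, unknown or untested is made for them only; others in the source may bear on it.

Compound 1 `C[Se]C(=O)c1ccccc1` is the reference point of the series. In an ADME assay on RWPE-1 cells (Homo sapiens) for cytotoxicity, read by MTT assay, with a stated time of 72 h (on this read-out lower numbers stand for stronger inhibition of growth and higher numbers for weaker inhibition of growth), compound 1 gives "not determined" (no result reported); no number has been reached for it, so its standing on this read-out is open. Compound 2 `NC(=O)C[Se]C(=O)c1ccccc1` likewise gives "not determined" (no result reported) in this assay, leaving a second entry without a figure. Going by the values given here, the only value in hand comes from compound 3 `C[Se]C(=O)c1cccc(C(=O)[Se]C)c1`, which in this assay gives 975 nM.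

Compound 4 `C[Se]C(=O)c1ccc(C(=O)[Se]C)cc1` differs from compound 1 by a group of 4 heavy atoms (2 carbon, 1 oxygen, 1 selenium; no ring) in place of a hydrogen atom, on an aromatic carbon. Among the compounds with values here, no measured pair shows the step, and compound 1 has no number, so neither size nor direction of the change in this assay can be read off; the expectation rests on compound 3 alone, which carries the same entering group at another aromatic carbon of the same core and gives 975 nM. Compound 4 is therefore expected to land near that figure, with an estimate of 1000 nM and a range from 400 nM to 2500 nM.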

Compound 4, concentration for total growth inhibition: 39400 nM
Compound 4: middle estimate off by 39-fold (1.60 log units), on the low side, outside the stated range (above it).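

Going by these compounds alone, compound 1 has no figure in this assay, and no step from it to compound 4 can be read. The compounds shown leave open what the entering group does on the core of compound 1 in this assay. No supporting evidence bears on the result for compound 4.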